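Replacing the pyridyl arm of compound 2 with methylsulfanyl

This account rests on a few compounds, and the source may have more. Where it says the series, first, only, none or still open, it means among the compounds named here.

Measured compounds:
- Compound 1, `O=C(CCCCCCc1ccccc1)c1ncc(-c2ccccc2C(=O)C(F)(F)F)o1`: 5000 nM
- Compound 2, `Cc1ccc(-c2cnc(C(=O)CCCCCCc3ccccc3)o2)nc1`: 2.8 nM
- Compound 3, `COC(=O)c1ccc(-c2cnc(C(=O)CCCCCCc3ccccc3)o2)nc1`: 3.5 nM

The series was tested in an assay (Rattus norvegicus) for inhibition of Fatty-acid amide hydrolase 1 (Homo sapiens); on this read-out lower numbers stand for stronger inhibition and higher numbers for weaker inhibition. Compound 2 gives the lowest of the three numbers; compound 3 lies nearest to it, and the step of a 1.3-fold higher number from compound 2 to compound 3 (0.10 log units; within the scatter) sits within the scatter, so the two cannot be ordered. Compound 1, by contrast, gives a number far higher than that of compound 2.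

The next compound, compound 4, `CSc1cnc(C(=O)CCCCCCc2ccccc2)o1`, differs from compound 2 in one place: methylsulfanyl in place of 5-methylpyridin-2-yl on an aromatic carbon. Among the compounds with values here, no measured step bears directly on this change. Within the data shown here, the only measured step, from compound 2 to compound 3, swaps one substituent on the pyridine for another and leaves the pyridine itself in place, and it is within the scatter. Here the whole pyridine leaves and a much smaller group enters, so that step gives no guide to size. What the data do show is that compound 1, where the group at this place is altered, gives 5000 nM, a far weaker result than compound 2 in this assay.

On that basis the step of a 71-fold higher number from compound 2 to compound 4 (1.85 log units; beyond the scatter) is expected to be a loss. Compound 4 is estimated at 200 nM, with a range from 40 nM to 1000 nM.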

Compound 4, inhibition constant: 25 nM
Estimate against measurement, compound 4: 8.0-fold (0.90 log units) above; measured number outside the range, below it.
By their numbers in this assay, from the lowest: compounds 2 and 3 (each within the scatter of the next); then compound 4; then compound 1.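

In this assay, putting methylsulfanyl in place of 5-methylpyridin-2-yl, on the aromatic carbon next to the ring oxygen, gives an 8.9-fold higher number from compound 2 to compound 4 (0.95 log units; beyond the scatter) and so a loss that is real but modest. This shows that a ring is not needed in this place for a nanomolar number: the entering group has 2 heavy atoms and no ring against the 7 heavy atoms of the group that leaves, yet compound 4 gives 25 nM, whereas compound 1, with a different aromatic group in the same place, gives 5000 nM. The compounds shown carry no measurement that explains the size of this step.

They leave open whether the loss follows the removal of the ring or the change of the linking atom, a question that a methoxy group, a methylsulfonyl group or an ethylsulfanyl group in this place would bear on. They also leave open how far a plain hydrogen, a chlorine atom or an unsubstituted phenyl group here would stand from compound 2 and compound 4.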